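The source may report more compounds than this note shows. Statements on the series, on what has been measured and on what is new or still open speak of the compounds shown alone.

Measured so far:
- compound 1, `O=C(CCC(=O)c1ccccc1)Nc1nc2ccc(F)cc2s1`: 300 mg/kg
- compound 2, `COc1ccc2nc(NC(=O)CCC(=O)c3ccccc3)sc2c1`: 30 mg/kg

Both were run in a functional assay on the whole organism with Mus musculus as the target, in the maximal electroshock model, with a stated time of 4 h; on this read-out higher numbers stand for an effect only at larger amounts of compound and lower numbers for an effect already at smaller amounts. Within the data shown here, compound 2 holds the lowest number of the two measured; its nearest neighbour is compound 1, and the only measured step, a 10-fold lower number from compound 1 to compound 2 (1.00 log units; beyond the scatter), lies beyond the scatter.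

Compound 3, `CC(=O)c1ccc2nc(NC(=O)CCC(=O)c3ccccc3)sc2c1`, is not yet measured. It differs from compound 2 as follows: acetyl in place of methoxy on an aromatic carbon.

Among the measured compounds shown here, the one measured step bears only loosely on this change, since it swapped fluoro for methoxy rather than replacing methoxy by a larger group. Nothing measured here shows how acetyl behaves at this position. With a single step as reference, no direction can be argued firmly; the expectation is a step in this assay of a 2.0-fold higher number from compound 2 to compound 3 (0.30 log units; within the scatter) for compound 3, small and possibly within the scatter. The minimum effective dose of compound 3 is expected at about 60 mg/kg, with a range of 20 mg/kg to 300 mg/kg.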

Compound 3, minimum effective dose: 100 mg/kg
Estimate against measurement, compound 3: 1.7-fold (0.22 log units) below; low and high end bracket the measured number.
By their numbers in this assay, from the lowest: compound 2; then compound 3; then compound 1.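

In this assay, acetyl in place of methoxy gives a 3.3-fold higher number from compound 2 to compound 3 (0.52 log units; beyond the scatter) on this aromatic carbon, so the low number of compound 2 does not carry over to the other oxygen-bearing group tested here. Acetyl in place of fluoro gives a 3.0-fold lower number from compound 1 to compound 3 (0.48 log units; beyond the scatter) and places acetyl between the two earlier groups, with methoxy lowest and fluoro highest, and both gaps lie beyond the scatter. This position therefore separates three groups rather than two, yet that order alone gives no rule, and no supporting data explain it.

As far as these compounds go, whether an amine, a carboxylic acid or a longer chain at this position would fall below compound 2 remains open. Also open, from the compounds shown here alone, is whether the same order of methoxy, acetyl and fluoro holds when the phenyl ketone side of the shared core is changed.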